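The compounds below may be only part of what the source reports. "The series", "measured", "known", "first", "only" and "open" are said of these compounds alone.

Compound 1 `Cn1c(Cc2nn(C)c(=O)c3ccccc23)nnc1SCC(=O)Nc1ccc(Cl)cc1Cl` gives 21100 nM in an assay on 32D cells for inhibition of interleukin-15 (Mus musculus), read by resazurin assay, with stated times of 30 min and 2.5 days, in the presence of a further agent that is not named here (on this read-out higher numbers stand for weaker inhibition and lower numbers for stronger inhibition), and stands highest of the two numbers in the series. Compound 2 `Cn1nc(Cc2nnc(SCC(=O)Nc3ccc(Cl)cc3Cl)n2CCC=O)c2ccccc2c1=O` gives 6400 nM in this assay. The step is a 3.3-fold lower number from compound 1 to compound 2 (0.52 log units; beyond the scatter). Compound 3 `Cn1nc(Cc2nnc(SCC(=O)Nc3ccc(Cl)cc3Cl)n2CCC(=O)O)c2ccccc2c1=O` reaches only the assay limit of > 30000 nM in this assay, at which 1 of the 3 values shown sits, in this assay, recorded as > 30000 nM. The related steps are an at least 1.4-fold higher number from compound 1 to compound 3 (0.15 log units; that floor lies within the scatter) and an at least 4.6-fold higher number from compound 2 to compound 3 (0.67 log units; beyond the scatter). Compound 4 `Cn1c(Cc2nn(CCC3OCCO3)c(=O)c3ccccc23)nnc1SCC(=O)Nc1ccc(Cl)cc1Cl` carries the change ((1,3-dioxolan-2-yl)methyl in place of hydrogen on a saturated chain carbon bound to an aromatic nitrogen). The step from compound 1 to compound 2 bears on it most, since the formylmethyl there also sits on a saturated chain carbon bound to an aromatic nitrogen, while the hydroxy-bearing chain of compound 3 gives no gain. A modest fall is expected, a 2.1-fold lower number from compound 1 to compound 4 (0.32 log units; beyond the scatter). Compound 4 is estimated at 10000 nM, between 4000 nM and 30000 nM.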

Compound 4, half-maximal inhibitory concentration: > 30000 nM
Compound 4 was reported as a limit; the forecaster's own chance of this, stated with the estimate: 15%; at least 3.0-fold (0.47 log units) between middle value and limit.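

The step is an at least 1.4-fold higher number from compound 1 to compound 4 (0.15 log units; that floor lies within the scatter), so (1,3-dioxolan-2-yl)methyl on a saturated chain carbon bound to an aromatic nitrogen shows no gain over hydrogen, and the size of any loss cannot be fixed. The fall with formylmethyl, a 3.3-fold lower number from compound 1 to compound 2 (0.52 log units; beyond the scatter), therefore does not extend to this larger ring-bearing group. The reading for compound 4 is a limit, which compound 3 shares: the limit of > 30000 nM in this assay, at which 2 of the 4 values shown sit.

On these data alone, what stays open is how far compound 4 lies past that limit. As far as these compounds go, whether an amine or a longer alkyl chain on the same carbon would match compound 2 also remains open.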